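Sulfonyl aryl substituent change: chloro to methyl

A few compounds are considered here, and "the series" means these few. Any claim that something is new, unique, unknown or untested is made for them only; others in the source may bear on it.

Measured so far:
compound 1, `CC1=NC(c2cn(S(=O)(=O)c3ccc(F)cc3)c3ccc(C)cc23)CN1`: > 30000 nM (a limit)
compound 2, `CC1=NC(c2cn(S(=O)(=O)c3ccccc3Cl)c3ccc(C)cc23)CN1`: 1500 nM

In an assay on isolated protein for inhibition of kallikrein-7 (Mus musculus), read by fluorescence, with stated times of 10 min and 30 min (a lower number here means a stronger inhibitor, a higher number a weaker inhibitor), compound 1 reaches only a limit, > 30000 nM, and reports no number. Compound 1 thus sits at the limit of > 30000 nM in this assay, at which 1 of the 2 values shown sits. Compound 2 gives 1500 nM in this assay; it is the only number shown in the series. For the measured compounds named here, the single measured step is an at least 20-fold lower number from compound 1 to compound 2 (1.30 log units; beyond the scatter), a large change that exchanges both the halogen and the substituent position on the phenyl on the sulfonyl sulfur.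

Compound 3, `CC1=NC(c2cn(S(=O)(=O)c3ccccc3C)c3ccc(C)cc23)CN1`, differs from compound 2 in one place: methyl in place of chloro on an aromatic carbon. The measured step from compound 1 to compound 2 does not isolate chloro against methyl, so it bears on this change only loosely, by showing that the substituent on this ring matters strongly. Going by the values given here, with no step comparing these two groups directly, compound 3 is expected to move little from compound 2, by no change at the digits printed from compound 2 to compound 3 (within the scatter), a step estimated to lie within the scatter. Compound 3 is therefore estimated at 1500 nM, with a range of 500 nM to 5000 nM.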

Compound 3, half-maximal inhibitory concentration: 1300 nM
Compound 3: the middle estimate sits 1.2-fold (0.06 log units) above what was measured, within the range that was stated.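

In this assay, the change from 2-chlorophenyl to 2-methylphenyl is a 1.2-fold lower number from compound 2 to compound 3 (0.06 log units; within the scatter), so this position on the ring on the sulfonyl sulfur does not tell chloro and methyl apart. The other step, an at least 23-fold lower number from compound 1 to compound 3 (1.36 log units; beyond the scatter), shows that the gain seen with compound 2 is not tied to chlorine, as a group holding only carbon at the same place carries it as well. Compound 1 reaches only a limit, and that step gives a bound rather than a size, because one end of it is no number: the limit of > 30000 nM in this assay, at which 1 of the 3 values shown sits.

Both steps away from 4-fluorophenyl change the substituent and its place on the ring together, so the compounds shown do not say which of the two accounts for the gap, a question that a pair such as 2-fluorophenyl and 4-methylphenyl would address. As far as these compounds go, how far this position tolerates other groups also stays open, for example methoxy, trifluoromethyl or an amine in the place of the methyl of compound 3.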